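Replacing 3,4-difluorophenyl with pyridin-3-yl in compound 1

The source may report more compounds than this note shows. Statements on the series, on what has been measured and on what is new or still open speak of the compounds shown alone.

compound 1 `COc1ccc(S(=O)(=O)N2CCc3cccc(-c4ccc(F)c(F)c4)c32)cc1` gives 46 nM in a functional assay on KB-VIN10 cells (Homo sapiens) for inhibition, with a stated time of 72 h; on this read-out higher numbers stand for weaker inhibition and lower numbers for stronger inhibition
compound 2 `COc1ccc(S(=O)(=O)N2CCc3cccc(-c4cc(OC)c(OC)c(OC)c4)c32)cc1` gives 4670 nM in this assay
compound 3 `COc1ccc(S(=O)(=O)n2ccc3cccc(-c4ccc(C#N)cc4)c32)cc1` gives 146 nM in this assay

In this assay compound 1 has the lowest of the three numbers, and both other values lie beyond the scatter from it. Compound 4 `COc1ccc(S(=O)(=O)N2CCc3cccc(-c4cccnc4)c32)cc1` carries pyridin-3-yl in place of 3,4-difluorophenyl on an aromatic carbon of the core of compound 1. For the measured compounds named here, no measured pair differs in one place only, so any expectation is loose. Compound 2 at 4670 nM shows that values with another aryl group on this core can climb far. A moderate rise beyond the scatter is expected in this assay, meaning weaker inhibition. The expected change is a 3.7-fold higher number from compound 1 to compound 4 (0.57 log units; beyond the scatter) on current evidence. The estimated value for compound 4 is 170 nM within an expected range of 45 nM to 700 nM for now.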

Compound 4, half-maximal inhibitory concentration: 84.5 nM
Compound 4: the middle estimate sits 2.0-fold (0.30 log units) above what was measured, within the range that was stated.
By their numbers in this assay, from the lowest: compounds 1, 4 and 3 (each within the scatter of the next, the first and the last beyond it); then compound 2.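

In this assay, pyridin-3-yl in place of 3,4-difluorophenyl on an aromatic carbon of the shared core gives a 1.8-fold higher number from compound 1 to compound 4 (0.26 log units; within the scatter), so the two groups cannot be told apart on this read-out. This first single-place comparison shows that the position tolerates a ring with a hetero atom and a hydrogen-bond acceptor, with no step beyond the scatter. No evidence on any property bears on this step.

Still open, on these data alone, is whether a carboxylic acid or an aminomethyl group on the same aromatic carbon would stay within the scatter of compound 1.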